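Methyl added to the fused ring of compound 1

This account rests on a few compounds, and the source may have more. Where it says the series, first, only, none or still open, it means among the compounds named here.

Working notes on a small set of related inhibitors, all measured in an assay on isolated protein for inhibition of alpha-ketoglutarate-dependent dioxygenase alkB homolog 3 (Homo sapiens), read by polymerase chain reaction, with a stated time of 1 h; a higher number here means a weaker inhibitor, a lower number a stronger inhibitor. Compound 1 `Cc1[nH]n(-c2nc3c(C)cccc3[nH]2)c(=O)c1Cc1ccccc1` gives 5900 nM, the higher of the two numbers recorded so far. Its nearest neighbour in value is compound 3 `Cc1ccc2[nH]c(-n3[nH]c(C)c(Cc4ccccc4Cl)c3=O)nc2c1`, which gives 910 nM; the gap between the two is beyond the usual scatter of this assay. Compound 2 `Cc1[nH]n(-c2nc3ccccc3s2)c(=O)c1C` sits at a limit of this assay, > 10000 nM, and no number is known for it; this is the point described by the limit of > 10000 nM in this assay, at which 1 of the 3 values shown sits.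

The next compound in the series is compound 4 `Cc1ccc2[nH]c(-n3[nH]c(C)c(Cc4ccccc4)c3=O)nc2c1C`, which differs from compound 1 in one place: methyl in place of hydrogen on an aromatic carbon. Among the measured compounds shown here, no pair of measured compounds shows the effect of this exact change, so there is no measured step to lean on. The expectation for this assay is a step of modest size, most likely within the scatter, with a slight lean toward a lower number. Compound 4 is therefore expected to give about 4500 nM, with a plausible range from 1500 nM to 13000 nM, an expected step from compound 1 to compound 4 of a 1.3-fold lower number from compound 1 to compound 4 (0.12 log units; within the scatter).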

Compound 4, half-maximal inhibitory concentration: > 10000 nM
Compound 4: only a limit was reported; the forecaster's own chance of this, stated with the estimate: 20%; at least 2.2-fold (0.34 log units) between middle value and limit.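

In this assay compound 4 gives > 10000 nM, which is a limit of the assay and not a number. Among the compounds shown here, this is the first change that can be read in one place: methyl in place of hydrogen on an aromatic carbon, ortho to a methyl group, gives an at least 1.6-fold higher number from compound 1 to compound 4 (0.22 log units; that floor lies within the scatter), so the added methyl brings no lower number at this position, while the true size of the step stays unknown. The reading of this step ends at the assay's limit, which now applies to more of the compounds shown: the limit of > 10000 nM in this assay, at which 2 of the 4 values shown sit.

The compounds shown leave open how far the true value of compound 4 lies from compound 1, and so whether the change costs little or much, and whether the result belongs to methyl specifically or to any group on this aromatic carbon. A methoxy group, a fluorine atom or an amine at the same place would help to separate these readings, provided the values fall inside the measurable range of this assay.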